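The source may hold more compounds than are shown below. What is called first, only, known or untested is meant among the compounds shown, and "the series" means these compounds.

The series rests on the shared core of compound 1 `COc1cc(Cl)cc(-c2nn(-c3cccc(NC(=O)Nc4ccc(Cl)c(C(F)(F)F)c4)c3)cc2-c2ccncc2)c1` and compound 2 `COc1cc(Cl)cc(-c2nn(-c3cccc(NC(=O)Nc4cccc(C(F)(F)F)c4)c3)cc2-c2ccncc2)c1`. In a functional assay on HT-29 cells (Homo sapiens) for inhibition, read by sulforhodamine B assay, with a stated time of 48 h, tested at 0.01 uM (on this read-out lower numbers stand for a stronger effect and higher numbers for a weaker effect at the one concentration tested), compound 1 gives 101%. In this assay compound 2 gives 102%, the highest of the two numbers, and its nearest neighbour is compound 1. For the measured compounds named here, the only step measured so far, a number 1 percentage points higher from compound 1 to compound 2 (within the scatter), leaves both within the scatter of each other, and neither number shows any inhibition worth the name at the single concentration used.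

Compound 3 `COc1cc(Cl)cc(-c2nn(-c3cccc(NC(=O)c4cccc(C(F)(F)F)c4)c3)cc2-c2ccncc2)c1` has not yet been measured in this assay. It differs from compound 2 by 3-(trifluoromethyl)phenyl in place of (3-(trifluoromethyl)phenyl)amino on a carbonyl carbon. Going by the values given here, no measured step touches the carbonyl carbon or its neighbours; the one step available concerns a chloro on a different ring and was itself within the scatter, so it offers no direct precedent for this change. Among the compounds with values here, with both measured numbers sitting close together and no relevant step to draw on, the expectation for compound 3 is a step of a number 2 percentage points lower from compound 2 to compound 3 (within the scatter), that is, none beyond the scatter. Compound 3 is therefore estimated at 100% in this assay, with a range from 86% to 112%.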

Compound 3, a percentage reported as activity, at one concentration (the size of the read-out at that concentration, not a potency): 90%
Estimate against measurement, compound 3: 10 percentage points above; the range from low to high includes it.
By their numbers in this assay, from the lowest: compound 3; then compounds 1 and 2 (each within the scatter of the next).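

In this assay, for the compounds shown here, 3-(trifluoromethyl)phenyl in place of (3-(trifluoromethyl)phenyl)amino on the carbonyl carbon gives a number 12 percentage points lower from compound 2 to compound 3 (beyond the scatter) and so provides the first step that lies beyond the scatter, showing that the read-out responds to a change at this position. The same result appears when the group that leaves is (4-chloro-3-(trifluoromethyl)phenyl)amino, with a number 11 percentage points lower from compound 1 to compound 3 (beyond the scatter), so the finding holds for both amino groups shown on this carbonyl carbon. Nothing measured here accounts for the step.

Still open, as far as these compounds go, is whether the amino nitrogen itself matters or whether the result depends on the particular aryl group attached to the carbonyl carbon, a question that a benzyl group, a morpholine or a plain methyl at this place would address. With compound 3 at 90% in this assay at a single concentration, the shown data also leave open how this change would read at higher concentrations, or with a carboxylic acid or a primary amine on the terminal ring.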